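Pyridin-4-yl in Place of Oxetan-3-yl on the Amide Nitrogen

The source may report more compounds than this note shows. Statements on the series, on what has been measured and on what is new or still open speak of the compounds shown alone.

Three compounds have been measured in an assay on HEK293 cells for agonist activity at transient receptor potential cation channel subfamily M member 8 (Homo sapiens), read by fluorescence and calcium flux, with a stated time of 15 min; a higher number here means that more compound is needed for the effect, a lower number that less compound is needed:
compound 1, `Cc1ccc(OCC(=O)N(Cc2cccs2)C2COC2)cc1`, gives 23000 nM;
compound 2, `CCN(Cc1cccn1C)C(=O)COc1ccc(C)cc1`, gives 21300 nM;
compound 3, `CCN(Cc1cccs1)C(=O)C[C@H](O)c1ccccc1`, gives 52000 nM.

Compound 1 stands second highest of these three numbers. Its nearest neighbour is compound 2, whose value lies within the usual scatter of compound 1, so the two cannot be told apart. Compound 3 lies furthest away, with a number beyond the scatter, higher than that of compound 1.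

The unmeasured compound 4, `Cc1ccc(OCC(=O)N(Cc2cccs2)c2ccncc2)cc1`, is compound 1 with one change: pyridin-4-yl in place of oxetan-3-yl on an amide-type nitrogen. For the measured compounds named here, no pair of measured compounds shows a step of this kind, so the size of the step is open. A modest move toward a lower number is expected for compound 4, close to the edge of the scatter, giving a 1.6-fold lower number from compound 1 to compound 4 (0.22 log units; within the scatter). Compound 4 is therefore estimated at 14000 nM, with a range from 4500 nM to 45000 nM.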

Compound 4, half-maximal effective concentration: 52 nM
Beside the measured number, compound 4's estimate is 270-fold (2.43 log units) above it; measured number outside the range, below it.
By their numbers in this assay, from the lowest: compound 4; then compounds 2 and 1 (each within the scatter of the next); then compound 3.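

In this assay, the group on this amide-type nitrogen turns out to matter greatly: pyridin-4-yl in place of oxetan-3-yl gives a 440-fold lower number from compound 1 to compound 4 (2.65 log units; beyond the scatter). Both groups are rings with one hetero atom, one hydrogen-bond acceptor and no hydrogen-bond donor, so these counts alone do not separate them; they differ in ring size, aromatic character and the hetero atom. Nothing available explains a step of this size. Still open, on these data alone, is whether the aromatic ring or the position of its nitrogen matters most, which a cyclohexyl or pyridin-3-yl group on this nitrogen would help separate.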